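Azole swap at the thiazole position, toward a pyrazole

A few compounds are considered here, and "the series" means these few. Any claim that something is new, unique, unknown or untested is made for them only; others in the source may bear on it.

Three compounds share one amide core and differ only in the five-membered ring on the dimethylated benzene. Compound 1 `Cc1cc(C)c(-c2ncc[nH]2)cc1NC(=O)c1ccc(OCc2ccccn2)cc1` gives 2000 nM in a physicochemical assay for solubility, at pH 7.4; a higher number here means a more soluble compound, a lower number a less soluble compound. Compound 2 `Cc1cc(C)c(-c2cn(C)cn2)cc1NC(=O)c1ccc(OCc2ccccn2)cc1` gives 8000 nM in this assay, a change described by a 4.0-fold higher number from compound 1 to compound 2 (0.60 log units; beyond the scatter). Compound 3 `Cc1csc(-c2cc(NC(=O)c3ccc(OCc4ccccn4)cc3)c(C)cc2C)n1` reaches only the limit of < 1000 nM in this assay, so its true number is not known, as told by the limit of < 1000 nM in this assay, at which 1 of the 3 values shown sits. Against compound 1 the step is an at least 2.0-fold lower number from compound 1 to compound 3 (0.30 log units; that floor lies within the scatter), against compound 2 it is an at least 8.0-fold lower number from compound 2 to compound 3 (0.90 log units; beyond the scatter); on the numbers shown, compound 3 therefore stands at the low end of the three.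

Compound 4 `Cc1cc(C)c(-c2c[nH]nc2C)cc1NC(=O)c1ccc(OCc2ccccn2)cc1` carries the change (3-methyl-1H-pyrazol-4-yl in place of 4-methyl-1,3-thiazol-2-yl on an aromatic carbon). For the measured compounds named here, no measured step involves a pyrazole, but both steps into compound 3 point the same way, with the thiazole sitting at or beneath every azole measured. Returning to an azole bearing a donor is expected to move the number back up, and the step from compound 3 to compound 4 in this assay is estimated as an at least 2.0-fold higher number from compound 3 to compound 4 (0.30 log units; that floor lies within the scatter). Compound 4 is expected to give about 2000 nM in this assay, in a range from 800 nM to 5000 nM.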

Compound 4, solubility: 33000 nM
For compound 4 the middle estimate is 17-fold (1.22 log units) below the measured one; measured number above the stated range.
By their numbers in this assay, from the lowest: compound 1; then compound 2; then compound 4. At a limit, below all of these: compound 3.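

In this assay the 3-methyl-1H-pyrazol-4-yl group stands above both imidazole-bearing compounds, with a 4.1-fold higher number from compound 2 to compound 4 (0.62 log units; beyond the scatter) and a 17-fold higher number from compound 1 to compound 4 (1.22 log units; beyond the scatter). Put in place of 4-methyl-1,3-thiazol-2-yl, at an equal count of heavy atoms, it gives an at least 33-fold higher number from compound 3 to compound 4 (1.51 log units; beyond the scatter), which shows a wider span at this position than the earlier compounds showed. That step is a floor, since compound 3 stands at a limit: the limit of < 1000 nM in this assay, at which 1 of the 4 values shown sits.

What the compounds shown leave open is how much of this rise belongs to the pyrazole ring itself and how much to its methyl group, and how a 1H-pyrazol-4-yl carrying no methyl, or an ethyl group or an amine in its place, would read in this assay. Why the azoles fall in this order also stays open.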